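Replacing the Substituted Phenyl of Compound 3

A few compounds are considered here, and "the series" means these few. Any claim that something is new, unique, unknown or untested is made for them only; others in the source may bear on it.

Among the three measured compounds, compound 3 `O=C(Nc1cccnc1)c1ccccc1OCc1c(Cl)cccc1Cl` stands lowest in an assay on lysate for inhibition of phosphatidylcholine:ceramide cholinephosphotransferase 2 (Homo sapiens), read by HPLC, with stated times of 30 min and 2 h (on this read-out higher numbers stand for weaker inhibition and lower numbers for stronger inhibition), with 690 nM. Compound 2 `O=C(Nc1cccnc1)c1ccccc1OCc1c(F)cccc1Cl` gives 1500 nM and compound 1 `N#Cc1cccc(COc2ccccc2C(=O)Nc2cccnc2)c1` gives 60700 nM. The steps of a 40-fold lower number from compound 1 to compound 2 (1.61 log units; beyond the scatter) and an 88-fold lower number from compound 1 to compound 3 (1.94 log units; beyond the scatter) were large, while a 2.2-fold lower number from compound 2 to compound 3 (0.34 log units; beyond the scatter) was modest. Compound 4 `Cc1ccc(Cl)cc1COc1ccccc1C(=O)Nc1cccnc1` differs from compound 3 in one place: 5-chloro-2-methylphenyl in place of 2,6-dichlorophenyl on a saturated chain carbon bound to an oxygen on an aromatic ring. Within the data shown here, the large steps from compound 1 show that changing this phenyl can move the number greatly, while the modest step from compound 2 to compound 3 shows that exchanging one halogen for another moves it little; no measured step covers a methyl or a single chlorine on this phenyl. Compound 4 is therefore expected to give a somewhat higher number, a 2.9-fold higher number from compound 3 to compound 4 (0.46 log units; beyond the scatter). The value of compound 4 is estimated at 2000 nM, within a range from 600 nM to 7000 nM.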

Compound 4, half-maximal inhibitory concentration: 1100 nM
Beside the measured number, compound 4's estimate is 1.8-fold (0.26 log units) above it, within the range that was stated.
By their numbers in this assay, from the lowest: compounds 3, 4 and 2 (each within the scatter of the next, the first and the last beyond it); then compound 1.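

In this assay the 5-chloro-2-methylphenyl of compound 4 stands with the two halogen-bearing phenyls, with a 1.6-fold higher number from compound 3 to compound 4 (0.20 log units; within the scatter) and a 1.4-fold lower number from compound 2 to compound 4 (0.13 log units; within the scatter) as its steps, so a second halogen on this phenyl is not required. The 3-cyanophenyl of compound 1 remains apart, with a 55-fold lower number from compound 1 to compound 4 (1.74 log units; beyond the scatter) as the step. Nothing given here explains this result.
The compounds shown leave open whether this phenyl needs a chlorine at all, and how an amine, a carboxylic acid or a methoxy group on it would read.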